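From tert-butyl to 4-methoxyphenyl on the amide carbonyl

This account rests on a few compounds, and the source may have more. Where it says the series, first, only, none or still open, it means among the compounds named here.

In a functional assay on K562 cells (Homo sapiens) for antiproliferative activity (a lower number here means a stronger inhibitor, a higher number a weaker inhibitor), compound 1 `CCCC(=O)N[C@H]1[C@H]2OC(C)(C)O[C@H]2O[C@@H]1[C@H](O)CO` gives 20000000 nM. For the measured compounds named here, compound 2 `CC1(C)O[C@H]2O[C@H]([C@H](O)CO)[C@@H](NC(=O)C(C)(C)C)[C@H]2O1` gives 20000000 nM, which leaves compound 2 level with compound 1, the only other compound measured so far. Both numbers are very high on this scale, so both compounds are very weak inhibitors.

Compound 3 `COc1ccc(C(=O)N[C@H]2[C@H]3OC(C)(C)O[C@H]3O[C@@H]2[C@H](O)CO)cc1` keeps the shared core and differs from compound 2 at the same place that separates compounds 1 and 2: 4-methoxyphenyl in place of tert-butyl on a carbonyl carbon. In words, this puts 4-methoxyphenyl in place of tert-butyl on a carbonyl carbon.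

Going by the values given here, only one measured step bears on this change. It is no change at the digits printed from compound 1 to compound 2 (within the scatter), and it put tert-butyl in place of propyl. That step offers no sign that this place matters in this assay, but it is thin evidence, since neither measured compound has an aromatic ring there. No step beyond the scatter is therefore expected, although a gain in potency remains possible. The expected step is a 1.3-fold lower number from compound 2 to compound 3 (0.12 log units; within the scatter). Compound 3 is estimated at 15000000 nM, with an expected range of 4000000 nM to 25000000 nM.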

Compound 3, half-maximal inhibitory concentration: 2500000 nM
Beside the measured number, compound 3's estimate is 6.0-fold (0.78 log units) above it; measured number outside the range, below it.
By their numbers in this assay, from the lowest: compound 3; then compounds 1 and 2 (each within the scatter of the next).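

In this assay, this position does respond to the group on the carbonyl carbon: 4-methoxyphenyl gives a clear gain over tert-butyl (an 8.0-fold lower number from compound 2 to compound 3 (0.90 log units; beyond the scatter)) and the same gain over propyl (an 8.0-fold lower number from compound 1 to compound 3 (0.90 log units; beyond the scatter)). The earlier pair gave no sign of this, since propyl and tert-butyl could not be told apart here, so the position only proved sensitive once the non-ring groups gave way to a group with one six-membered aromatic ring and one hydrogen-bond acceptor. Nothing available shows what lies behind this gain.

The change brings in the aromatic ring and the methoxy group together, so these compounds cannot show whether the ring alone is enough; a plain phenyl group on the carbonyl carbon would separate the two. They also leave open whether other groups at this place, such as a chlorophenyl, a pyridine ring or a longer chain, would lower the number further, which matters since compound 3 still sits very high on this scale and remains a weak inhibitor.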